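The source may hold more compounds than are shown below. What is called first, only, known or untested is meant among the compounds shown, and "the series" means these compounds.

Among the measured compounds shown here, in a functional assay on MCF7 cells (Homo sapiens) for antiproliferative activity, read by sulforhodamine B assay, with a stated time of 72 h (on this read-out lower numbers stand for stronger inhibition and higher numbers for weaker inhibition), compound 1 `COc1ccc(NC(=O)Cn2nc(Cc3ccccc3)c3ccccc3c2=O)cc1` gives 62000 nM, while compound 2 `O=C(Cn1nc(Cc2ccccc2)c2ccccc2c1=O)Nc1cccc(Cl)c1` gives 10800 nM, the lower of the two numbers measured so far. The next compound, compound 3 `O=C(Cn1nc(Cc2ccccc2)c2ccccc2c1=O)Nc1cccc(C(F)(F)F)c1`, keeps everything in compound 2 except one group: trifluoromethyl in place of chloro on an aromatic carbon. In words, trifluoromethyl takes the place of chloro on an aromatic carbon. For the measured compounds named here, only one measured step offers any guide, and only indirectly: a 5.7-fold lower number from compound 1 to compound 2 (0.76 log units; beyond the scatter), a modest step in which 3-chlorophenyl replaced 4-methoxyphenyl on an amide-type nitrogen. Going by the values given here, no measured pair shows the chloro to trifluoromethyl exchange itself, so no direction can be drawn from the data, and no step beyond the scatter is expected in this assay. The expected change is a 1.1-fold lower number from compound 2 to compound 3 (0.03 log units; within the scatter). For compound 3 the estimated value is 10000 nM, with an expected range from 4000 nM to 28000 nM.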

Compound 3, half-maximal inhibitory concentration: 3850 nM
Compound 3: middle estimate off by 2.6-fold (0.41 log units), on the high side; the measured number lies below the stated range.
By their numbers in this assay, from the lowest: compound 3; then compound 2; then compound 1.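

At this aromatic carbon, meta to a large group, the exchange of chloro for trifluoromethyl brings a 2.8-fold lower number from compound 2 to compound 3 (0.45 log units; beyond the scatter) in this assay, so the choice of group here matters. The earlier step changed both the group and its place on the ring at once, whereas this one holds the place fixed and changes only the group. Replacing 4-methoxyphenyl with 3-(trifluoromethyl)phenyl gives a 16-fold lower number from compound 1 to compound 3 (1.21 log units; beyond the scatter) and leaves compound 3 with the lowest number of the three. Nothing shown gives a measured reason for either drop. From the compounds shown here alone, whether a nitrile, an amine or a carboxylic acid on this same carbon would lower the number further remains open. So does whether trifluoromethyl would bring a similar step on another carbon of the ring.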